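Bromo to methoxycarbonyl on the fused ring of compound 3

The source may hold more compounds than are shown below. What is called first, only, known or untested is meant among the compounds shown, and "the series" means these compounds.

Three compounds of the series share one core and differ in the groups around it. Compound 1 `CCOc1nc2ccccn2c(=N)c1S(=O)(=O)c1ccccc1` gives 12 nM in an assay on HeLa cells for displacement of a labelled ligand from 5-hydroxytryptamine receptor 6 (Homo sapiens); a higher number here means a weaker inhibitor, a lower number a stronger inhibitor. Compound 2 `Cc1ccc(Nc2nc3ccc(C)cn3c(=N)c2S(=O)(=O)c2ccccc2)nc1` gives 60 nM in this assay. Compound 3 `CSc1nc2ccc(Br)cn2c(=N)c1S(=O)(=O)c1ccccc1` gives 56 nM in this assay, the second highest of the three numbers; its value and that of compound 2 lie within the scatter of each other, while the value of compound 1 lies beyond the scatter below it.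

Compound 4 `COC(=O)c1ccc2nc(SC)c(S(=O)(=O)c3ccccc3)c(=N)n2c1` is not yet measured. It differs from compound 3 in one place: methoxycarbonyl in place of bromo on an aromatic carbon. For the measured compounds named here, no measured pair isolates this change, so no step size can be taken from the data. The expectation is a step from compound 3 to compound 4 of a 1.4-fold higher number from compound 3 to compound 4 (0.15 log units; within the scatter), small and not clearly beyond the scatter in either direction. Compound 4 is estimated at 80 nM in this assay, with a range from 25 nM to 250 nM.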

Compound 4, half-maximal inhibitory concentration: 470 nM
Compound 4: middle estimate off by 5.9-fold (0.77 log units), on the low side, outside the stated range (above it).
By their numbers in this assay, from the lowest: compound 1; then compounds 3 and 2 (each within the scatter of the next); then compound 4.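

In this assay, for the compounds shown here, the aromatic carbon two atoms from the ring nitrogen proves sensitive to its substituent: methoxycarbonyl in place of bromo gives an 8.4-fold higher number from compound 3 to compound 4 (0.92 log units; beyond the scatter) and supplies the first step that isolates a single place. The change replaces one heavy atom with four and adds two hydrogen-bond acceptors, and this single pair cannot separate those differences. Nothing measured here explains the weaker binding.

Open, from the compounds shown here alone, is which part of the methoxycarbonyl group carries the step, a question that a carboxylic acid, a primary amide or a chloro group at this position would help to settle. Also open, going by these compounds, is whether a step of this size would recur with the ethoxy group of compound 1 on the shared core.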